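Thiomorpholine to morpholine swap on the extended side chain

This account rests on a few compounds, and the source may have more. Where it says the series, first, only, none or still open, it means among the compounds named here.

compound 1 `CCCCc1nc(C)c(CC(=O)N2CCSCC2)c(=O)n1Cc1ccc(-c2ccccc2-c2nnn[nH]2)cc1` — 0.038 mg/kg
compound 2 `CCCCc1nc(C)c(CC(=O)N2CCOCC2)c(=O)n1Cc1ccc(-c2ccccc2-c2nnn[nH]2)cc1` — 0.018 mg/kg
compound 3 `CCCCc1nc(C)c(CCC(=O)N2CCSCC2)c(=O)n1Cc1ccc(-c2ccccc2-c2nnn[nH]2)cc1` — 0.204 mg/kg

Three measured compounds share one core and differ only at the amide end of the side chain. In an in vivo functional assay on the whole organism for inhibition, with Rattus norvegicus as the target (on this read-out lower numbers stand for an effect already at smaller amounts and higher numbers for an effect only at larger amounts of compound), compound 1 gives 0.038 mg/kg, compound 2 gives 0.018 mg/kg and compound 3 gives 0.204 mg/kg. The change from compound 1 to compound 2 is morpholin-4-yl in place of thiomorpholin-4-yl on a carbonyl carbon; it made a 2.1-fold lower number from compound 1 to compound 2 (0.32 log units; beyond the scatter). The core of compound 3 differs from the core of compound 1 by ((thiomorpholin-4-yl)carbonyl)methyl in place of (thiomorpholin-4-yl)carbonyl on a saturated chain carbon bound to an aromatic carbon, a change that made a 5.4-fold higher number from compound 1 to compound 3 (0.73 log units; beyond the scatter). Between compound 2 and compound 3 the step is an 11-fold higher number from compound 2 to compound 3 (1.05 log units; beyond the scatter), so the longer chain carries the weaker pair of the series so far.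

Compound 4 `CCCCc1nc(C)c(CCC(=O)N2CCOCC2)c(=O)n1Cc1ccc(-c2ccccc2-c2nnn[nH]2)cc1` is not yet measured. It differs from compound 3 by morpholin-4-yl in place of thiomorpholin-4-yl on a carbonyl carbon, which is the same change as that from compound 1 to compound 2, now made on the longer chain of compound 3. Among the compounds with values here, only one earlier instance of this change is known, so the expectation rests on a single step and carries wide bounds. For compound 4 a step of a 2.0-fold lower number from compound 3 to compound 4 (0.31 log units; beyond the scatter) is expected, close to the earlier one, because a 2.1-fold lower number from compound 1 to compound 2 (0.32 log units; beyond the scatter). Compound 4 is estimated at 0.1 mg/kg, with a range from 0.04 mg/kg to 0.25 mg/kg.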

Compound 4, dose for half-maximal effect: 0.143 mg/kg
The estimate for compound 4 lay 1.4-fold (0.16 log units) below the measured number; measured number inside the range.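

In this assay, the change from thiomorpholin-4-yl to morpholin-4-yl on a carbonyl carbon gives steps on the two cores that do not differ: the same change on two cores in this assay, a 2.1-fold lower number (0.32 log units; beyond the scatter) from compound 1 to compound 2 and a 1.4-fold lower number (0.15 log units; within the scatter) from compound 3 to compound 4, 1.5-fold (0.17 log units) apart, within the scatter of two such steps

This supports carrying the change from the shorter side chain to the longer one as a small step at most, but it does not establish a gain on the longer chain, where a 1.4-fold lower number from compound 3 to compound 4 (0.15 log units; within the scatter) leaves the two compounds unseparated, and two instances make no general rule for the series. What separates the compounds more clearly is the side chain, with a 7.9-fold higher number from compound 2 to compound 4 (0.90 log units; beyond the scatter) for the morpholine pair, while a 3.8-fold higher number from compound 1 to compound 4 (0.58 log units; beyond the scatter) combines the chain change with the ring change and so cannot be assigned to either one alone.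

On these data alone, whether the same near-neutral result holds for a piperidin-1-yl or dimethylamino group on the carbonyl carbon remains open, as does the effect of replacing the amide with a carboxylic acid. As far as these compounds go, it is also open whether a chain longer than 2-((morpholin-4-yl)carbonyl)ethyl would continue the trend seen with these compounds or whether the two ring groups would then separate.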